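The source may report more compounds than this note shows. Statements on the series, on what has been measured and on what is new or still open speak of the compounds shown alone.

Measured compounds in this series:

- compound 1, `CCN1CCN(Cc2ccc(NC(=O)Nc3ccc(Oc4cc(NC(C)=O)ncn4)cc3)cc2C(F)(F)F)CC1`: 38 nM
- compound 3, `CC(=O)Nc1cc(Oc2ccc(NC(=O)Nc3ccc(CN4CCN(C)CC4)c(C(F)(F)F)c3)cc2)ncn1`: 50 nM
- compound 2, `Cc1ccc(NC(=O)Nc2ccc(Oc3cc(NCCN)ncn3)cc2)cc1C(F)(F)F`: reported only as a limit, > 10000 nM

In a functional assay on BaF3 cells (Mus musculus) for inhibition, read by CCK-8 assay, with a stated time of 72 h (a higher number here means a weaker inhibitor of growth, a lower number a stronger inhibitor of growth), compound 1 gives 38 nM and compound 3 gives 50 nM. Among the compounds with values here, the one measured step, a 1.3-fold higher number from compound 1 to compound 3 (0.12 log units; within the scatter), concerns a saturated ring carbon on the opposite side of the shared core and does not touch the position that changes here. Compound 2 stands at the limit of this assay, > 10000 nM, so it gives no number to build on; the evidence is the limit of > 10000 nM in this assay, at which 1 of the 3 values shown sits. Compound 4, `Cc1ccc(NC(=O)Nc2ccc(Oc3cc(N4CCN[C@H](C)C4)ncn3)cc2)cc1C(F)(F)F`, is the next compound to be measured. Its change from compound 2 is 3-methylpiperazin-1-yl in place of (2-aminoethyl)amino on an aromatic carbon. Within the data shown here, no measured step covers this exchange. What can be said is that compound 1 and compound 3, which carry acetamido at this place, sit at low values in this assay, while compound 2 with (2-aminoethyl)amino sits at the limit. Compound 4 is therefore estimated at 3000 nM, with a range from 300 nM to 10000 nM, and a fair chance that it again returns only a limit. The expected step is an at least 3.3-fold lower number from compound 2 to compound 4 (0.52 log units; beyond the scatter), which can only be stated as a lower bound on improvement since compound 2 has no number.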

Compound 4, concentration for 50% growth inhibition: 8920 nM
Compound 4: the middle estimate sits 3.0-fold (0.47 log units) below what was measured; the range from low to high includes it.
By their numbers in this assay, from the lowest: compounds 1 and 3 (each within the scatter of the next); then compound 4. At a limit, above all of these: compound 2.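

In this assay compound 4 gives 8920 nM on the same core as compound 2, so with 3-methylpiperazin-1-yl on this aromatic carbon the series has a reading that is a number and not a limit. Compound 2 stands only at a limit, > 10000 nM in this assay. The exchange of (2-aminoethyl)amino for 3-methylpiperazin-1-yl therefore has only a floor, an at least 1.1-fold lower number from compound 2 to compound 4 (0.04 log units; that floor lies within the scatter) and on that floor alone no gain beyond the scatter is shown, so its true size stays unknown: the limit of > 10000 nM in this assay, at which 1 of the 4 values shown sits.

Still open, from the compounds shown here alone, is how acetamido on this aromatic carbon reads on the core of compound 4, which would link that core to compound 3 by a single change, and how 3-methylpiperazin-1-yl reads on the core of compound 3. Also open, going by these compounds, is what a plain piperazine, a morpholine or the opposite configuration at the defined stereocentre gives at this place, and whether any of these moves the number well clear of the limit.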